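A few compounds are considered here, and "the series" means these few. Any claim that something is new, unique, unknown or untested is made for them only; others in the source may bear on it.

Measured compounds:
- compound 1, `O=[N+]([O-])c1cc2c(OCCC3CCCCN3)c(-c3cc(C(F)(F)F)cc(C(F)(F)F)c3)c(O)nc2cc1Cl`, 71 nM
- compound 2, `Cc1cc(C)cc(-c2c(O)nc3cc(Cl)c(NC(=O)Nc4cccnc4)cc3c2OCCC2CCCCN2)c1`, 20 nM

Both compounds were tested in a functional assay on cells (Pituitary gland cell) for antagonist activity at Gonadotropin-releasing hormone receptor (Rattus norvegicus); a higher number here means a weaker inhibitor, a lower number a stronger inhibitor. Compound 2 has the lower of the two numbers, and the gap to compound 1 is beyond the usual scatter, so on these two numbers compound 2 is the stronger inhibitor. The two compounds differ in several places at once, so no single structural change can be tied to that gap.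

Compound 3, `Cc1cc(C)cc(-c2c(O)nc3cc(Cl)c(NC(=O)Nc4ccccn4)cc3c2OCCC2CCCCN2)c1`, has not yet been measured. It differs from compound 2 in one place only: pyridin-2-yl in place of pyridin-3-yl on an amide-type nitrogen. The same atoms are present in both; only the point at which the ring is joined to the amide-type nitrogen changes, so the ring still carries one hydrogen-bond acceptor and no donor.

Within the data shown here, no measured pair shows what such a change does in this assay, so there is no precedent to lean on. The expected step of a 1.3-fold higher number from compound 2 to compound 3 (0.10 log units; within the scatter) is therefore small, most likely within the scatter, in either direction. Compound 3 is estimated at 25 nM, with a range from 8 nM to 80 nM.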

Compound 3, half-maximal inhibitory concentration: 15 nM
Beside the measured number, compound 3's estimate is 1.7-fold (0.22 log units) above it; measured number inside the range.
By their numbers in this assay, from the lowest: compounds 3 and 2 (each within the scatter of the next); then compound 1.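

Compounds 2 and 3 are the only pair shown that differ in one place, so a single change can be read in this assay: pyridin-2-yl in place of pyridin-3-yl on an amide-type nitrogen gives a 1.3-fold lower number from compound 2 to compound 3 (0.12 log units; within the scatter). The same atoms are present in both compounds and only the point at which the ring is joined has changed, yet in this assay the two compounds cannot be told apart, so at this position the result does not depend measurably on which of these two attachment points is used. Nothing measured here speaks to why the two numbers stay so close.

From the compounds shown here alone, whether pyridin-4-yl, a plain phenyl ring or a small methyl group on the same amide-type nitrogen would also stay within the scatter remains open, as this step compares only two ways of joining one ring. Going by these compounds, compound 1 differs from compound 2 in several places, so what its nitro group and its trifluoromethyl groups each contribute on their own also remains open.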